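This account rests on a few compounds, and the source may have more. Where it says the series, first, only, none or still open, it means among the compounds named here.

Measured compounds in a functional assay on HEK293 cells with D(4) dopamine receptor (Homo sapiens) as the target, read by FLIPR; on this read-out higher numbers stand for an effect only at larger amounts of compound and lower numbers for an effect already at smaller amounts:
compound 1 `CO/N=C(\CCN1CCC(c2ccccn2)CC1)c1ccc(Cl)cc1`: 195 nM
compound 2 `CO/N=C(/CCN1CCC(c2ccccn2)CC1)c1ccc(Cl)cc1`: in this assay compound 2 reaches only the limit of > 10000 nM
compound 3 `CO/N=C(\CCN1CCC(c2cccc[n+]2[O-])CC1)c1ccc(Cl)cc1`: 84 nM

Compound 3 has the lowest of the two numbers reported in this assay; its nearest neighbour is compound 1, which stands higher by the step from compound 1 to compound 3 of a 2.3-fold lower number from compound 1 to compound 3 (0.37 log units; beyond the scatter), a modest change brought about by the pyridine N-oxide in place of the pyridine on the saturated ring carbon. For compound 2 this assay reports a limit rather than a number, which the limit of > 10000 nM in this assay, at which 1 of the 3 values shown sits, makes explicit.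

The next compound, compound 4 `CO/N=C(/CCN1CCC(c2cccc[n+]2[O-])CC1)c1ccc(Cl)cc1`, keeps every atom and bond of compound 3 and differs only in this respect: the two compounds have the same atoms and bonds and differ only in configuration as drawn: 1 of 1 stereo elements differ; a double bond is drawn E in compound 3 and Z in compound 4. Among the measured compounds shown here, one measured step bears directly on such a change: from compound 1 to compound 2, the same flip of the drawn double bond produced an at least 51-fold higher number from compound 1 to compound 2 (1.70 log units; beyond the scatter), a large loss, and the fact that compounds 1 and 2 differ only in the configuration as drawn shows that nothing else distinguishes those two compounds. A step of comparable size is therefore expected from compound 3 to compound 4, a 120-fold higher number from compound 3 to compound 4 (2.08 log units; beyond the scatter), and the result for compound 4 is expected to sit at 10000 nM, plausibly between 3000 nM and 40000 nM, with a substantial chance that this assay again returns only a limit.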

Compound 4, half-maximal effective concentration: 46.4 nM
Estimate against measurement, compound 4: 220-fold (2.33 log units) above, and the stated range ends above it.
By their numbers in this assay, from the lowest: compounds 4 and 3 (each within the scatter of the next); then compound 1. At a limit, above all of these: compound 2.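

On the pyridine core, the flip of the drawn double bond gave an at least 51-fold higher number from compound 1 to compound 2 (1.70 log units; beyond the scatter) in this assay, yet on the pyridine N-oxide the same flip gives a 1.8-fold lower number from compound 3 to compound 4 (0.26 log units; within the scatter) and so leaves no change that can be read beyond the scatter: the fact that compounds 3 and 4 differ only in the configuration as drawn. The pyridine N-oxide in place of the pyridine likewise behaves differently on the two double-bond forms, with a 2.3-fold lower number from compound 1 to compound 3 (0.37 log units; beyond the scatter) on the E form but an at least 210-fold lower number from compound 2 to compound 4 (2.33 log units; beyond the scatter) on the Z form. The configuration of the double bond and the group on the saturated ring carbon therefore do not act independently in these four compounds: the same change on two cores in this assay, a 2.3-fold lower number (0.37 log units; beyond the scatter) from compound 1 to compound 3 and an at least 210-fold lower number (2.33 log units; beyond the scatter) from compound 2 to compound 4, at least 92-fold (1.96 log units) apart, beyond the scatter of two such steps.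

As far as these compounds go, compound 2 gives only a limit, so the full size of its step to compound 4 stays open: the limit of > 10000 nM in this assay, at which 1 of the 4 values shown sits. It also remains open whether the flip of the double bond would cost as much or as little with a phenyl ring or a carboxylic acid in place of the pyridine N-oxide, since the pairing is shown here for only two groups.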